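Chlorophenyl ketone in the trimethoxyphenyl pyrazole chalcone series

The compounds below may be only part of what the source reports. "The series", "measured", "known", "first", "only" and "open" are said of these compounds alone.

Three enones sharing one core have been run in a functional assay on MDA-MB-231 cells (Homo sapiens) for inhibition, read by MTT assay, with a stated time of 48 h; a higher number here means a weaker inhibitor, a lower number a stronger inhibitor. Compound 1 `COc1cc(-c2cc(/C=C/C(=O)c3ccc(N)cc3)[nH]n2)cc(OC)c1OC` gives 2000 nM, compound 2 `COc1ccc(C(=O)/C=C/c2cc(-c3cc(OC)c(OC)c(OC)c3)n[nH]2)cc1` gives 950 nM, and compound 3 `COc1ccc(C(=O)/C=C/c2cc(-c3cc(OC)c(OC)c(OC)c3)n[nH]2)cc1F` gives 2700 nM. Compound 3 sits at the high end of the three numbers: its gap to compound 1 is within the scatter a 1.4-fold higher number from compound 1 to compound 3 (0.13 log units; within the scatter), while the step of a 2.8-fold higher number from compound 2 to compound 3 (0.45 log units; beyond the scatter) is beyond it.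

Compound 4 `COc1cc(-c2cc(/C=C/C(=O)c3ccc(Cl)cc3)[nH]n2)cc(OC)c1OC` differs from compound 3 by 4-chlorophenyl in place of 3-fluoro-4-methoxyphenyl on a carbonyl carbon. Among the compounds with values here, no measured pair carries a chlorine, so the bearing is indirect. The step of a 2.8-fold higher number from compound 2 to compound 3 (0.45 log units; beyond the scatter) shows what the fluoro adds, and the step of a 2.1-fold lower number from compound 1 to compound 2 (0.32 log units; beyond the scatter) shows methoxy against amino; compound 4 removes both the fluoro and the methoxy at once. The expectation in this assay is therefore a modest move back down from compound 3, with wide uncertainty, as a 1.8-fold lower number from compound 3 to compound 4 (0.26 log units; within the scatter). Compound 4 is estimated at 1500 nM, within a range of 500 nM to 5000 nM.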

Compound 4, half-maximal inhibitory concentration: 26000 nM
Beside the measured number, compound 4's estimate is 17-fold (1.24 log units) below it, outside the stated range (above it).
By their numbers in this assay, from the lowest: compound 2; then compounds 1 and 3 (each within the scatter of the next); then compound 4.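

In this assay the aromatic carbon carrying the chloro group proves far less tolerant than the amino, methoxy and fluoro variations suggested: chloro in place of methoxy gives a 27-fold higher number from compound 2 to compound 4 (1.44 log units; beyond the scatter) and chloro in place of amino gives a 13-fold higher number from compound 1 to compound 4 (1.11 log units; beyond the scatter) as well. Even against the highest of the earlier numbers, 4-chlorophenyl in place of 3-fluoro-4-methoxyphenyl on the carbonyl carbon gives a 9.6-fold higher number from compound 3 to compound 4 (0.98 log units; beyond the scatter) and so exceeds the whole spread among compound 1, compound 2 and compound 3. Nothing available explains this loss.

Still open, as far as these compounds go, is whether the loss belongs to chlorine specifically, which an unsubstituted phenyl, 4-fluorophenyl or 4-methylphenyl ketone would help to settle. A hydroxy or dimethylamino group on the same aromatic carbon would also test how widely the level of compound 2 holds.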